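The source may hold more compounds than are shown below. What is called first, only, known or untested is meant among the compounds shown, and "the series" means these compounds.

Measured in an in vitro ADME assay on microsomes from liver (Macaca fascicularis) for metabolic stability; on this read-out lower numbers stand for slow clearance and higher numbers for fast clearance:
Compound 1 `CCC(CC)[C@@H]1C(=O)N[C@H](C2Cc3ccccc3C2)C(=O)N1[C@@H](C(=O)N1CCOCC1)c1ccc(C)nc1`: 18 mL.min-1.g-1
Compound 2 `CCC(CC)[C@@H]1C(=O)N[C@H](C2Cc3ccccc3C2)C(=O)N1[C@@H](C(=O)N1CCOCC1)c1ccc(C)nc1C`: 14 mL.min-1.g-1

Among the compounds with values here, compound 1 stands within the scatter of compound 2, the only other compound measured. Compound 3 `CC[C@@H](C)[C@@H]1C(=O)N[C@H](C2Cc3ccccc3C2)C(=O)N1[C@@H](C(=O)N1CCOCC1)c1ccc(C)nc1` has sec-butyl in place of pentan-3-yl on a saturated ring carbon. Within the data shown here, the one measured step, a 1.3-fold lower number from compound 1 to compound 2 (0.11 log units; within the scatter), is methyl in place of hydrogen on an aromatic carbon, so it bears on this change only weakly. Among the measured compounds shown here, no step at the saturated ring carbon has been measured. In this assay, the expected outcome is a 1.2-fold lower number from compound 1 to compound 3 (0.08 log units; within the scatter), nothing beyond the scatter. The estimate for compound 3 is 15 mL.min-1.g-1, with an expected range of 8 mL.min-1.g-1 to 28 mL.min-1.g-1.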

Compound 3, intrinsic clearance in microsomes: 8 mL.min-1.g-1
For compound 3 the middle estimate is 1.9-fold (0.27 log units) above the measured one, within the range that was stated.
By their numbers in this assay, from the lowest: compounds 3, 2 and 1 (each within the scatter of the next, the first and the last beyond it).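

In this assay, within the data shown here, sec-butyl in place of pentan-3-yl on the saturated ring carbon gives the first step at this position (a 2.3-fold lower number from compound 1 to compound 3 (0.35 log units; beyond the scatter)), and it is a modest one beyond the scatter, unlike the earlier step on the aromatic carbon. The read-out therefore moves with the chain at this ring carbon, though this rests on a single pair. Nothing measured here accounts for the step. The compounds shown leave open whether ethyl or cyclopentyl at this carbon would take the number further. They also leave open whether sec-butyl and the added methyl of compound 2 would combine.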